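The source may hold more compounds than are shown below. What is called first, only, known or untested is meant among the compounds shown, and "the series" means these compounds.

Measured compounds in an ADME assay for metabolic stability, read by LC-MS, with a stated time of 3 h, at pH 6.5, tested at 50 uM; on this read-out lower numbers stand for a less stable compound and higher numbers for a more stable compound:

Compound 1 `C[C@@H](O)[C@H]1C(=O)N2C(C(=O)OCOC(=O)OC(C)(C)C)=C(S[C@@H]3CN[C@H](C(=O)Nc4cccc(C(=O)O)c4)C3)[C@H](C)[C@H]12`. In this assay compound 1 gives > 95%, which is a limit of the assay and not a number.
Compound 2 `CCC(CC)C(=O)OCOC(=O)C1=C(S[C@@H]2CN[C@H](C(=O)Nc3cccc(C(=O)O)c3)C2)[C@H](C)[C@@H]2[C@@H]([C@@H](C)O)C(=O)N12`. In this assay compound 2 gives > 95%, again a limit of the assay.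
Compound 3 `C[C@@H](O)[C@H]1C(=O)N2C(C(=O)OCOC(=O)OC3CCCCC3)=C(S[C@@H]3CN[C@H](C(=O)Nc4cccc(C(=O)O)c4)C3)[C@H](C)[C@H]12`. In this assay compound 3 gives > 95%, also a limit of the assay.

Compound 3 therefore stands at the limit, as do the other two: the limit of > 95% in this assay, at which 3 of the 3 values shown sit. None of the steps among the measured compounds can be read, since both ends of each sit at the limit: a step that the two limits leave unreadable from compound 1 to compound 2, a step that the two limits leave unreadable from compound 1 to compound 3, a step that the two limits leave unreadable from compound 2 to compound 3.

Compound 4 `C[C@@H](O)[C@H]1C(=O)N2C(C(=O)OCOC(=O)C3CCCCC3)=C(S[C@@H]3CN[C@H](C(=O)Nc4cccc(C(=O)O)c4)C3)[C@H](C)[C@H]12` differs from compound 3 as follows: cyclohexyl in place of cyclohexyloxy on a carbonyl carbon. The closest measured comparison is compound 2, which also carries a carbon group, pentan-3-yl, on the carbonyl carbon in place of an oxygen-linked group and still sits at the limit, > 95%. With every measured compound at the limit and no readable step, no change beyond the scatter is expected; the step from compound 3 to compound 4 is estimated at a step that the limit leaves unreadable from compound 3 to compound 4. Compound 4 is thus expected to give 96%, in the range 88% to 100%, most likely again reported only as the limit.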

Compound 4, percent of the compound remaining: > 95%
Compound 4 gave a limit, no number; the forecaster's own chance of this, stated with the estimate: 80%; the middle value is on the limit's open side.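

In this assay compound 4 gives > 95%, a limit and not a number. The steps from compound 1, compound 2 and compound 3 to compound 4 cannot be read: the limit of > 95% in this assay, at which 4 of the 4 values shown sit.

The compounds shown leave open how far these four differ in stability, and which change on the carbonyl carbon would yield a readable number.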